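Working notes: hydroxy substitution and tolerated concentration in three bis-aryl dienones

The compounds below may be only part of what the source reports. "The series", "measured", "known", "first", "only" and "open" are said of these compounds alone.

Measured so far in an ADME assay on PC-12 cells (Rattus norvegicus) for cytotoxicity, read by WST assay, with a stated time of 24 h; a lower number here means that less compound is tolerated, a higher number that more compound is tolerated:
compound 1, `O=C(/C=C/c1cccc(O)c1O)CC(=O)/C=C/c1cccc(O)c1O`: 39000 nM
compound 2, `O=C(/C=C/c1ccccc1O)CC(=O)/C=C/c1cccc(O)c1O`: 34000 nM
compound 3, `O=C(/C=C/c1cccc(O)c1)CC(=O)/C=C/c1cc(O)ccc1O`: 15000 nM

Compound 2 and compound 1 differ by one change, (hydroxy in place of hydrogen on an aromatic carbon), and the step was a 1.1-fold higher number from compound 2 to compound 1 (0.06 log units; within the scatter). Compound 3 carries the same atoms as compound 2, joined differently; how its core differs from that of compound 2 is not broken down here. In this assay compound 3 gives the lowest number of the three, beyond the scatter against both compound 2 and compound 1.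

Compound 4, `O=C(/C=C/c1cc(O)ccc1O)CC(=O)/C=C/c1cc(O)ccc1O`, has not yet been measured in this assay. It differs from compound 3 by hydroxy in place of hydrogen on an aromatic carbon. Within the data shown here, this is the same kind of change as the one from compound 2 to compound 1, but not the same: there the entering hydroxy sat ortho to a hydroxy group and meta to a large group, whereas here it sits ortho to a large group and para to a hydroxy group. Among the measured compounds shown here, the only measured example of this kind of change, from compound 2 to compound 1, stayed within the scatter, and nothing else speaks for a large step. The step from compound 3 to compound 4 is therefore expected to be small, about a 1.1-fold higher number from compound 3 to compound 4 (0.05 log units; within the scatter), because the earlier step was a 1.1-fold higher number from compound 2 to compound 1 (0.06 log units; within the scatter). For compound 4 in this assay the estimate is 17000 nM, with the range 8000 nM to 36000 nM.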

Compound 4, half-maximal cytotoxic concentration: 24000 nM
Compound 4: the middle estimate sits 1.4-fold (0.15 log units) below what was measured, within the range that was stated.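

In this assay, hydroxy in place of hydrogen on an aromatic carbon gave a 1.6-fold higher number from compound 3 to compound 4 (0.20 log units; within the scatter), so on this second core the change again produces no step beyond the scatter, and the two steps compare as follows: the same change on two cores in this assay, a 1.1-fold higher number (0.06 log units; within the scatter) from compound 2 to compound 1 and a 1.6-fold higher number (0.20 log units; within the scatter) from compound 3 to compound 4, 1.4-fold (0.14 log units) apart, within the scatter of two such steps

Within these two pairs, the change therefore carries from one core to the other without a detectable difference, and adding this hydroxy leaves the tolerated concentration within the scatter in both. Among these compounds, this does not show that the step is the same at every place on the ring or on every core: the entering hydroxy does not occupy the same place in the two pairs, only two pairs are available, and steps this small could hide a modest real difference.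

All ring substituents shown are hydroxy groups, so it remains open whether a methoxy group, a fluorine, an amine or a carboxylic acid at the same places would also leave the number within the scatter. Also open, going by these compounds, is whether the same holds on a core with a longer chain joining the two aromatic rings.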